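This account rests on a few compounds, and the source may have more. Where it says the series, first, only, none or still open, it means among the compounds named here.

Two analogues of a shared core have been measured so far. Compound 1 `COc1ccc(OC)c(S(=O)(=O)NC2=NCCN2C(=S)SN2CCn3c2nsc3=S)c1` carries a 2,5-dimethoxyphenyl group on a sulfonyl sulfur. In a functional assay on KYSE-510 cells (Homo sapiens) for antiproliferative activity, read by crystal violet staining, with a stated time of 96 h (a lower number here means a stronger inhibitor of growth, a higher number a weaker inhibitor of growth), compound 1 gives >= 20000 nM, which is a limit of the assay rather than a number. Compound 2 `O=S(=O)(NC1=NCCN1C(=S)SN1CCn2c1nsc2=S)c1ccccc1Cl` carries a 2-chlorophenyl group on the sulfonyl sulfur instead. In this assay compound 2 gives >= 20000 nM, again a limit and not a number. The step that the two limits leave unreadable from compound 1 to compound 2 therefore cannot be read off, because of the limit of >= 20000 nM in this assay, at which 2 of the 2 values shown sit. Compound 3 `O=S(=O)(NC1=NCCN1C(=S)SN1CCn2c1nsc2=S)c1cccc2ccccc12` is the next member to be tested, and it differs from compound 1 in one place: naphthalen-1-yl in place of 2,5-dimethoxyphenyl on a sulfonyl sulfur. Among the compounds with values here, the only measured step that bears on this change is the one from compound 1 to compound 2, and since its size is unreadable it offers no guide to either direction or magnitude. The expectation for compound 3 is therefore that it also sits at the limit, with an estimated step that the limit leaves unreadable from compound 1 to compound 3. The value expected for compound 3 in this assay is 30000 nM, with a range from 10000 nM to 100000 nM.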

Compound 3, concentration for 50% growth inhibition: >= 20000 nM
Compound 3 gave a limit, no number (the forecaster's own chance of this, stated with the estimate: 80%); the middle value does not contradict the limit.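

Compound 3 adds no readable step against compound 1 or compound 2, because all three compounds give a limit and not a number: the limit of >= 20000 nM in this assay, at which 3 of the 3 values shown sit. In this assay the compounds shown leave open how strongly each inhibits growth, and whether 2,5-dimethoxyphenyl, 2-chlorophenyl or naphthalen-1-yl on the sulfonyl sulfur makes any difference.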